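The compounds below may be only part of what the source reports. "The series", "measured", "known", "first", "only" and "open" are said of these compounds alone.

Measured so far in a functional assay on the whole organism (strain Wistar albino) for inhibition, with Rattus norvegicus as the target, read by paw edema, with stated times of 30 min and 4 h, at a dose of 20 mg/kg by the oral route; on this read-out lower numbers stand for less inhibition and higher numbers for more inhibition at the one dose given (going by the name of the read-out): compound 1 `Cc1cc(=O)oc2cc(OC(=O)CNc3ccccc3[N+](=O)[O-])ccc12` gives 15.2%; compound 2 `Cc1cc(=O)oc2cc(OC(=O)CNc3ccccc3Cl)ccc12` gives 23.7%; compound 3 `Cc1cc(=O)oc2cc(OC(=O)CNc3cccc([N+](=O)[O-])c3)ccc12` gives 32.2%.

Compound 2 has the second highest of the three numbers, but its gaps to compound 1 and to compound 3 are each within the usual scatter, so the three can hardly be told apart. Compound 4 `Cc1cc(=O)oc2cc(OC(=O)CNN3C=NNC3)ccc12` differs from compound 2 in one place: a group of 5 heavy atoms (2 carbon, 3 nitrogen; one five-membered non-aromatic ring with 3 hetero atoms) in place of a group of 7 heavy atoms (6 carbon, 1 chlorine; one six-membered aromatic ring of carbon only), on an amine nitrogen. Within the data shown here, the only measured single-place step, a number 8.5 percentage points higher from compound 1 to compound 2 (within the scatter), exchanges one substituent on the aromatic ring and stays within the scatter; no measured step replaces the ring itself, so it bears only loosely on this change. In this assay compound 4 is therefore expected to move no further than the scatter, a number 0.3 percentage points higher from compound 2 to compound 4 (within the scatter). The estimate for compound 4 is 24%, with a range from 10% to 40%.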

Compound 4, a percentage reported as inhibition, in the whole organism at one dose (the size of the read-out at that dose, not a potency): 22.2%
For compound 4 the middle estimate is 1.8 percentage points above the measured one; the range from low to high includes it.
By their numbers in this assay, from the lowest: compounds 1, 4, 2 and 3 (each within the scatter of the next, the first and the last beyond it).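

In this assay, putting the five-membered non-aromatic ring with 3 hetero atoms in place of the 2-chlorophenyl on the amine nitrogen gives a number 1.5 percentage points lower from compound 2 to compound 4 (within the scatter). The earlier step only exchanged a substituent on the aromatic ring, whereas this one shows that the whole ring can be replaced at this position with no change beyond the scatter at this dose. No available data explain this result.

As far as these compounds go, it remains open whether a piperidine ring or a longer chain on the same nitrogen would also stay within the scatter of compound 2.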